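Closing the amide: cyclohexylamino to piperidin-1-yl

A few compounds are considered here, and "the series" means these few. Any claim that something is new, unique, unknown or untested is made for them only; others in the source may bear on it.

Compound 2 `Nc1nn(CC(=O)NC2CCCCC2)c2nc(-c3ccccc3)cc(C(F)(F)F)c12` holds the lowest of the two numbers recorded in a functional assay on HeLa cells (Homo sapiens) for cytotoxicity, read by MTT assay, with a stated time of 24 h (a lower number here means a stronger inhibitor, a higher number a weaker inhibitor), where compound 2 gives 3900 nM. Among the measured compounds shown here, its only neighbour, compound 1 `Nc1nn(CC(=O)NCCO)c2nc(-c3ccccc3)cc(C(F)(F)F)c12`, gives 69500 nM in this assay; the single recorded step, an 18-fold lower number from compound 1 to compound 2 (1.25 log units; beyond the scatter), was cyclohexyl in place of 2-hydroxyethyl on an amide-type nitrogen. Compound 3 `Nc1nn(CC(=O)N2CCCCC2)c2nc(-c3ccccc3)cc(C(F)(F)F)c12`, not yet measured, differs from compound 2 by piperidin-1-yl in place of cyclohexylamino on a carbonyl carbon. For the measured compounds named here, the one measured step bears only loosely on this change: it exchanged the group on the amide nitrogen while the amide hydrogen stayed, whereas here the six-membered ring is kept and the hydrogen-bond donor is lost. Going by the values given here, no recorded pair shows the effect of removing that donor. For compound 3 in this assay a step of a 1.4-fold higher number from compound 2 to compound 3 (0.15 log units; within the scatter) is therefore expected, small and not clearly beyond the scatter. The value of compound 3 is estimated at 5500 nM, with a range from 1500 nM to 22000 nM.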

Compound 3, half-maximal inhibitory concentration: 2900 nM
Compound 3: middle estimate off by 1.9-fold (0.28 log units), on the high side; the range from low to high includes it.
By their numbers in this assay, from the lowest: compounds 3 and 2 (each within the scatter of the next); then compound 1.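

In this assay, the step of a 1.3-fold lower number from compound 2 to compound 3 (0.13 log units; within the scatter) places piperidin-1-yl level with cyclohexylamino on this carbonyl carbon, so at this position the amide hydrogen of compound 2 is not required to reach this level in the two compounds with a six-membered ring. The step of a 24-fold lower number from compound 1 to compound 3 (1.38 log units; beyond the scatter) shows that replacing (2-hydroxyethyl)amino gives a large difference also when the incoming ring is piperidin-1-yl, as the step of an 18-fold lower number from compound 1 to compound 2 (1.25 log units; beyond the scatter) showed for cyclohexyl. Nothing available accounts for these results.

The compounds shown leave open whether a smaller pyrrolidin-1-yl ring, a morpholin-4-yl ring or an open-chain dimethylamino group on the same carbonyl carbon would stay at this level. Also open, from the compounds shown here alone, is what a carboxylic acid in place of the amide would give.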